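Chloroalkyl and chloroacetyl ureas: antiproliferative working notes

The source may report more compounds than this note shows. Statements on the series, on what has been measured and on what is new or still open speak of the compounds shown alone.

Measured so far:
Compound 1 `O=C(NCCCCl)Nc1ccc(I)cc1`: > 100000 nM, a limit of the assay.
Compound 2 `CCCCC(O)c1cccc(NC(=O)NCCCCl)c1`: > 100000 nM, a limit of the assay.
Compound 3 `CCCCC(OC)c1cccc(NC(=O)NCCCCl)c1`: 50000 nM.

In a functional assay on MCF7 cells (Homo sapiens) for antiproliferative activity, with a stated time of 48 h (on this read-out higher numbers stand for weaker inhibition and lower numbers for stronger inhibition), compound 1 and compound 2 report only limits, with the limit of > 100000 nM in this assay, at which 2 of the 3 values shown sit. Among the measured compounds shown here, compound 3 is the one compound of the three with a number in this assay. For the measured compounds named here, the only measured step, an at least 2.0-fold lower number from compound 2 to compound 3 (0.30 log units; that floor lies within the scatter), concerns the oxygen on the saturated carbon and has a floor within the scatter.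

Compound 4 `CCCCC(OC)c1cccc(NC(=O)NC(=O)CCl)c1` differs from compound 3 by (chloromethyl)carbonyl in place of 3-chloropropyl on an amide-type nitrogen. Going by the values given here, no measured step touches the amide-type nitrogen, so nothing measured bears on this change, and no step beyond the scatter is expected in this assay. Compound 4 is estimated at 30000 nM, between 5000 nM and 100000 nM, meaning an expected step of a 1.7-fold lower number from compound 3 to compound 4 (0.22 log units; within the scatter).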

Compound 4, half-maximal inhibitory concentration: 6100 nM
Compound 4: the middle estimate sits 4.9-fold (0.69 log units) above what was measured; the range from low to high includes it.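

On the amide-type nitrogen, (chloromethyl)carbonyl in place of 3-chloropropyl gives an 8.2-fold lower number from compound 3 to compound 4 (0.91 log units; beyond the scatter) in this assay. Among the compounds shown here, this is the first measured change at this nitrogen and the first step beyond the scatter. Compound 1 and compound 2 stay at a limit, so only compound 3 and compound 4 compare by number: the limit of > 100000 nM in this assay, at which 2 of the 4 values shown sit.

The change swaps the chain and adds a carbonyl together, so the compounds shown do not separate these two parts. As far as these compounds go, whether an acetyl group without chlorine or a bromoacetyl group on this nitrogen would keep the step remains open.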